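Replacing the hydroxyphenyl ring in a polar dihydropyridine ester

This account rests on a few compounds, and the source may have more. Where it says the series, first, only, none or still open, it means among the compounds named here.

Compound 2 `CC1=C(C(=O)OCc2cccnc2)C(c2cccc(O)c2)C2=C(CCCC2=O)N1` gives 1.21 in a physicochemical assay for lipophilicity, measured as octanol-water partition (a lower number here means a more polar compound, a higher number a more lipophilic compound), the lowest of the three numbers measured; compound 1 `CC1=C(C(=O)OCc2ccccn2)C(c2cccc(O)c2)C2=C(CCCC2=O)N1` gives 1.58 and compound 3 `CC1=C(C(=O)OCc2ccccn2)C(c2ccc([N+](=O)[O-])cc2)C2=C(CCCC2=O)N1` gives 1.88. Compound 4 `CC1=C(C(=O)OCc2cccnc2)C(c2cccs2)C2=C(CCCC2=O)N1` differs from compound 2 by thiophen-2-yl in place of 3-hydroxyphenyl on a saturated ring carbon. Among the measured compounds shown here, only one measured step touches the same position: a number 0.30 log units higher from compound 1 to compound 3 (within the scatter). For the measured compounds named here, that step exchanged one six-membered aromatic ring for another, while the change to compound 4 removes the hydrogen-bond donor altogether and brings in a five-membered ring with a sulfur atom, so no measured step covers it directly. A modest rise is therefore expected, a number 0.44 log units higher from compound 2 to compound 4 (beyond the scatter), and compound 4 is estimated at 1.65, between 1.3 and 2.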

Compound 4, partition coefficient: 1.4
Compound 4: the middle estimate sits 0.25 log units above what was measured; the range from low to high includes it.
By their numbers in this assay, from the lowest: compounds 2, 4, 1 and 3 (each within the scatter of the next, the first and the last beyond it).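

In this assay, the exchange at this saturated ring carbon removes the hydrogen-bond donor of 3-hydroxyphenyl and a six-membered aromatic ring, yet it gives a number 0.19 log units higher from compound 2 to compound 4 (within the scatter). Together with a number 0.30 log units higher from compound 1 to compound 3 (within the scatter), this makes two different replacements of 3-hydroxyphenyl at this position, with pyridin-2-yl and pyridin-3-yl in the ester, that both stay within the scatter. Nothing available accounts for this result. The compounds shown leave open whether an amine or a carboxylic acid at this position would move the number beyond the scatter, and whether thiophen-2-yl behaves alike with pyridin-2-yl in the ester.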